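Chain to carbamate on the aromatic oxygen

The compounds below may be only part of what the source reports. "The series", "measured", "known", "first", "only" and "open" are said of these compounds alone.

Compound 2 `CC(C)=CCC/C(C)=C/COc1cc(=O)n(CCCO)c2c1CC(C/C=C(\C)CCC=C(C)C)C(C)(C)C2` stands second highest of the three numbers in a functional assay on PANC-1 cells (Homo sapiens) for inhibition, read by MTT assay, with a stated time of 24 h, tested at 10 uM (a higher number here means more inhibition at the concentration tested (going by the name of the read-out), a lower number less inhibition), giving 15.8%; compound 1 `CC(C)=CCC/C(C)=C/COc1cc(=O)n(CCCO)c2c1CC(CC=C(C)C)C(C)(C)C2` gives 10.6% and compound 3 `CC(C)=CCC/C(C)=C/CC1Cc2c(OCCCOc3ccc([N+](=O)[O-])cc3)cc(=O)n(CCCO)c2CC1(C)C` gives 65.1%. The step of a number 5.2 percentage points higher from compound 1 to compound 2 (within the scatter) lies within the scatter and says little. Compound 4 `COc1ccc(NC(=O)Oc2cc(=O)n(CCCO)c3c2CC(C/C=C(\C)CCC=C(C)C)C(C)(C)C3)cc1` differs from compound 2 by (4-methoxyphenyl)carbamoyl in place of 3,7-dimethylocta-2,6-dien-1-yl on an oxygen on an aromatic ring. The step that bears on this is a number 49.3 percentage points higher from compound 2 to compound 3 (beyond the scatter), where the chain on that same oxygen was also exchanged and the number rose strongly. A rise beyond the scatter is therefore expected for compound 4, though the entering group differs from that of compound 3, so the estimate does not reach the number that compound 3 gives, 65.1%. Compound 4 is expected to give 42%, ranging from 18% to 66%, an expected step of a number 26.2 percentage points higher from compound 2 to compound 4 (beyond the scatter).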

Compound 4, a percentage reported as inhibition, at one concentration (the size of the read-out at that concentration, not a potency): 64.1%
Compound 4: the middle estimate sits 22.1 percentage points below what was measured; low and high end bracket the measured number.
By their numbers in this assay, from the lowest: compounds 1 and 2 (each within the scatter of the next); then compounds 4 and 3 (each within the scatter of the next).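

On the oxygen on an aromatic ring, (4-methoxyphenyl)carbamoyl in place of 3,7-dimethylocta-2,6-dien-1-yl gives a number 48.3 percentage points higher from compound 2 to compound 4 (beyond the scatter) in this assay. Compound 4 and compound 3 lie within the scatter of each other, so a high number at this oxygen does not depend on a 2-(4-nitrophenoxy)ethyl ending, and a carbamate serves there too. No measured evidence bears on the origin of this rise. Still open, on these data alone, is whether a simple acetyl group on this oxygen, or a carbamate carrying an unsubstituted phenyl ring, holds the number.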